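A few compounds are considered here, and "the series" means these few. Any claim that something is new, unique, unknown or untested is made for them only; others in the source may bear on it.

Compound 1 `Cc1ccc(/C=N/NC(=O)CSc2nnc(-c3ccncc3)o2)cc1` is one of three measured compounds built on the same core. In a functional assay on MCF7 cells (Homo sapiens) for cytotoxicity, read by MTT assay, with a stated time of 48 h (on this read-out lower numbers stand for stronger inhibition and higher numbers for weaker inhibition), compound 1 gives 14700 nM, the highest number of the three. Compound 2 `O=C(CSc1nnc(-c2ccncc2)o1)N/N=C/c1ccccc1O` gives 4750 nM in this assay, and compound 3 `O=C(CSc1nnc(-c2ccncc2)o1)N/N=C/c1cc(Br)ccc1O` gives 7770 nM. Within the data shown here, the steps of a 3.1-fold lower number from compound 1 to compound 2 (0.49 log units; beyond the scatter) and a 1.9-fold lower number from compound 1 to compound 3 (0.28 log units; within the scatter) both replace the 4-methylphenyl on the carbon with a double bond to nitrogen, and they are the only steps that bear on compound 4 `O=C(CSc1nnc(-c2ccncc2)o1)N/N=C/c1ccco1`, whose change is furan-2-yl in place of 4-methylphenyl on a carbon with a double bond to nitrogen. Neither step tests a five-membered aromatic ring with 1 hetero atom, so a modest lowering or no change beyond the scatter is expected. Compound 4 is expected to show a 1.7-fold lower number from compound 1 to compound 4 (0.24 log units; within the scatter). The estimate for compound 4 is 8500 nM, with a range from 3000 nM to 25000 nM.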

Compound 4, half-maximal inhibitory concentration: 16600 nM
Compound 4: the middle estimate sits 2.0-fold (0.29 log units) below what was measured; the range from low to high includes it.
By their numbers in this assay, from the lowest: compounds 2, 3, 1 and 4 (each within the scatter of the next, the first and the last beyond it).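

In this assay, furan-2-yl on the carbon with a double bond to nitrogen does not separate from 4-methylphenyl (a 1.1-fold higher number from compound 1 to compound 4 (0.05 log units; within the scatter)). It therefore does not share the lower numbers of the groups carrying a hydroxy, as 2-hydroxyphenyl (a 3.5-fold higher number from compound 2 to compound 4 (0.54 log units; beyond the scatter)) and 5-bromo-2-hydroxyphenyl (a 2.1-fold higher number from compound 3 to compound 4 (0.33 log units; beyond the scatter)) show. Nothing measured here gives a reason for these steps. Still open, going by these compounds, is how thiophen-2-yl, another five-membered aromatic ring, would read in this place, and whether 2-methoxyphenyl or 2-aminophenyl would keep the lower number of 2-hydroxyphenyl.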